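Sulfonyl for cinnamoyl on the amine nitrogen

This account rests on a few compounds, and the source may have more. Where it says the series, first, only, none or still open, it means among the compounds named here.

Two compounds of the series carry a measured number. Compound 1 `CCCN(CC[C@H]1CC[C@H](NC(=O)/C=C/c2ccc(F)cc2)CC1)[C@H]1CCc2nc(N)sc2C1` gives 1 nM in an assay on brain for displacement of a labelled ligand from D(3) dopamine receptor (Rattus norvegicus); a higher number here means a weaker inhibitor, a lower number a stronger inhibitor. For the measured compounds named here, compound 2 `CCCN(CC[C@H]1CC[C@H](NC(=O)/C=C/c2cccc(Cl)c2)CC1)[C@H]1CCc2nc(N)sc2C1` gives 1.2 nM in this assay, the higher of the two numbers, yet the single measured step of a 1.2-fold higher number from compound 1 to compound 2 (0.08 log units; within the scatter) leaves it indistinguishable from compound 1. Compound 3 `CCCN(CC[C@H]1CC[C@H](NS(=O)(=O)c2ccccc2)CC1)[C@H]1CCc2nc(N)sc2C1` is the next member, not yet measured in this assay. Its change from compound 2 is phenylsulfonyl in place of (2-(3-chlorophenyl)ethenyl)carbonyl on an amine nitrogen. Going by the values given here, the one measured step exchanges only the aryl ring at the end of the chain and leaves the carbonyl on the amine nitrogen untouched, so no step bears on the exchange made here. The series therefore gives no measured anchor for this change, and the expectation rests on the shared core alone. Among the compounds with values here, compound 3 is estimated at 6 nM, within 1 nM to 40 nM, a step of a 5.0-fold higher number from compound 2 to compound 3 (0.70 log units; beyond the scatter) expected toward a weaker number, with a wide range because the series holds no comparable step.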

Compound 3, inhibition constant: 0.79 nM
Estimate against measurement, compound 3: 7.6-fold (0.88 log units) above, outside the stated range (below it).
By their numbers in this assay, from the lowest: compounds 3, 1 and 2 (each within the scatter of the next).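

In this assay, replacing (2-(3-chlorophenyl)ethenyl)carbonyl with phenylsulfonyl on the amine nitrogen gives a 1.5-fold lower number from compound 2 to compound 3 (0.18 log units; within the scatter), and replacing (2-(4-fluorophenyl)ethenyl)carbonyl with it gives a 1.3-fold lower number from compound 1 to compound 3 (0.10 log units; within the scatter). The earlier step changed only the aryl ring at the end of the chain, whereas these two steps show that the whole acyl group, including its carbonyl and ethenyl chain, can give way to phenylsulfonyl at this position with no change beyond the scatter. Nothing available explains why the numbers stay so close.

Still open, as far as these compounds go, is whether this holds for a sulfonyl group without an aryl ring, such as methylsulfonyl. The compounds shown also leave open how a chlorine or fluorine on the phenylsulfonyl ring would read in this assay.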